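The source may report more compounds than this note shows. Statements on the series, on what has been measured and on what is new or still open speak of the compounds shown alone.

Working notes on the series built around the shared core of compound 2 `O=C(CSc1snnc1-c1ccccc1)Nc1ccccc1Br`. In an ADME assay on MT4 cells (Homo sapiens) for cytotoxicity (a lower number here means that less compound is tolerated, a higher number that more compound is tolerated), compound 2 reaches only a limit, > 307000 nM. Compound 1 `Cc1ccc(NC(=O)CSc2snnc2-c2ccccc2)c(Br)c1` likewise gives only a limit in this assay, > 297000 nM. Compound 3 `O=C(CSc1snnc1-c1ccc(F)cc1F)Nc1ccccc1Br` gives 144000 nM in this assay. The step that the two limits leave unreadable from compound 1 to compound 2 cannot be read between two limits, while the step of an at least 2.1-fold lower number from compound 2 to compound 3 (0.32 log units; beyond the scatter) lowers the tolerated concentration. Compound 4 `O=C(CSc1snnc1-c1ccccc1)Nc1ccccc1[N+](=O)[O-]` differs from compound 2 by nitro in place of bromo on an aromatic carbon. Neither measured step concerns the group that changes here, so no direction is read from them. The expected step is an at least 1.2-fold lower number from compound 2 to compound 4 (0.08 log units; that floor lies within the scatter), nothing beyond the scatter. Compound 4 is therefore estimated at 250000 nM, with a range of 100000 nM to 400000 nM, and may again come back as a limit.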

Compound 4, half-maximal cytotoxic concentration: >= 246000 nM
Compound 4: only a limit was reported; the forecaster's own chance of this, stated with the estimate: 60%; the middle value does not contradict the limit.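

Compound 2 and compound 4 both give only limits in this assay; no step can be read between them. The compounds shown leave open whether nitro in place of bromo shifts the tolerated concentration at all.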